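Amide cap exchange: from compound 1 to compound 3

The source may hold more compounds than are shown below. What is called first, only, known or untested is meant among the compounds shown, and "the series" means these compounds.

Measured so far:
compound 1, `O=C(CCc1ccccc1)NCCCNc1nc(Nc2cccc(F)c2)ncc1Br`: 560 nM
compound 2, `O=C(NCCCNc1nc(Nc2cccc(F)c2)ncc1CC1CC1)C1CCC1`: > 1000 nM

Within the data shown here, in an assay on isolated protein for inhibition of serine/threonine-protein kinase TBK1 (Homo sapiens) (on this read-out higher numbers stand for weaker inhibition and lower numbers for stronger inhibition), compound 1 gives 560 nM, and this is the only numerical value available. For compound 2 the entry > 1000 nM is a limit of the assay and not a number (the limit of > 1000 nM in this assay, at which 1 of the 2 values shown sits). Among the measured compounds shown here, no two measured compounds differ in a single place, so no measured step exists against which a change could be weighed; compound 1 stands alone as the reference point.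

Compound 3, `CN1CCC(C(=O)NCCCNc2nc(Nc3cccc(F)c3)ncc2Br)CC1`, has not yet been measured in this assay. It differs from compound 1 by 1-methylpiperidin-4-yl in place of phenethyl on a carbonyl carbon. For the step from compound 1 to compound 3 a shift towards weaker inhibition, somewhat beyond the scatter, is expected, a 1.6-fold higher number from compound 1 to compound 3 (0.21 log units; within the scatter). Compound 3 is accordingly estimated at 900 nM, with a range from 250 nM to 3000 nM.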

Compound 3, half-maximal inhibitory concentration: 4300 nM
Estimate against measurement, compound 3: 4.8-fold (0.68 log units) below; the measured number lies above the stated range.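

Among these compounds, on a carbonyl carbon whose other neighbours are amide-type nitrogen, the only single-place change available is not neutral in this assay: 1-methylpiperidin-4-yl in place of phenethyl gives a 7.7-fold higher number from compound 1 to compound 3 (0.89 log units; beyond the scatter) and leaves compound 1 as the stronger of the two. The exchange replaces a six-membered aromatic ring of carbon only with a six-membered non-aromatic ring with 1 hetero atom, and the link to the carbonyl changes with it, so the step reads only as a change of the whole group. No measured property in the data accounts for this step.

Among the compounds shown here, compound 2 differs from compound 1 in more than one place, so no step to it can be read. From the compounds shown here alone, whether the step follows the ring nitrogen or the shorter link stays open: a cyclohexyl cap or a 2-(piperidin-4-yl)ethyl cap would separate the two.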